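The source may report more compounds than this note shows. Statements on the series, on what has been measured and on what is new or still open speak of the compounds shown alone.

In a functional assay on A549 cells (Homo sapiens) for cytotoxicity, read by MTT assay, with a stated time of 72 h (a higher number here means a weaker inhibitor, a lower number a stronger inhibitor), compound 1 `CN1CCN(CCCn2c3c(c4ccccc42)C(=O)c2c[n+]([O-])c4ccccc4c2C3=O)CC1` gives 140 nM and compound 2 `CN1CCN(CCCCCCn2c3c(c4ccccc42)C(=O)c2c[n+]([O-])c4ccccc4c2C3=O)CC1` gives 330 nM, the higher of the two numbers. Among the measured compounds shown here, the only measured step bearing on the next compound is modest: a 2.4-fold higher number from compound 1 to compound 2 (0.37 log units; beyond the scatter). Compound 3 `CN1CCN(CCCCCn2c3c(c4ccccc42)C(=O)c2c[n+]([O-])c4ccccc4c2C3=O)CC1` departs from compound 2 by 4-methylpiperazin-1-yl in place of (4-methylpiperazin-1-yl)methyl on a saturated chain carbon, five bonds along the chain from an aromatic nitrogen. This shortens the chain of compound 2 in the direction of compound 1, but covers only part of that measured step, so a slightly lower number in this assay is expected, probably within the scatter. The expected step is a 1.2-fold lower number from compound 2 to compound 3 (0.09 log units; within the scatter). The estimate for compound 3 is 270 nM, with an expected range of 130 nM to 520 nM.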

Compound 3, half-maximal inhibitory concentration: 870 nM
Compound 3: the middle estimate sits 3.2-fold (0.51 log units) below what was measured; measured number above the stated range.
By their numbers in this assay, from the lowest: compound 1; then compound 2; then compound 3.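

Shortening the chain of compound 2 moved the number away from that of compound 1, not toward it, with a 2.6-fold higher number from compound 2 to compound 3 (0.42 log units; beyond the scatter) in this assay and a 6.2-fold higher number from compound 1 to compound 3 (0.79 log units; beyond the scatter) in the same measure. Chain length at this position therefore acts in no single direction across these three compounds: compound 3, whose chain length lies between the other two, gives the highest number, and compound 2 goes against any steady rise with length. Nothing at hand explains this turn.

As far as these compounds go, whether a chain shorter than that of compound 1 or longer than that of compound 2 would lower the number remains open. So does whether a morpholine or a primary amine at the chain end would show the same turn.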